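The source may hold more compounds than are shown below. What is called first, only, known or untested is meant among the compounds shown, and "the series" means these compounds.

Compound 1 `N#Cc1cncc(N2CC[C@@H]3CN[C@@H]3C2)c1` carries a cyano group on an aromatic carbon. In a functional assay on HEK293 cells for agonist activity at Neuronal acetylcholine receptor; alpha3/beta4 (Homo sapiens), read by FLIPR (on this read-out higher numbers stand for an effect only at larger amounts of compound and lower numbers for an effect already at smaller amounts), compound 1 gives 490 nM. Compound 2 `COc1cncc(N2CC[C@@H]3CN[C@@H]3C2)c1` differs from compound 1 in one place: methoxy in place of cyano on an aromatic carbon. In this assay compound 2 gives 4500 nM, and the step is a 9.2-fold higher number from compound 1 to compound 2 (0.96 log units; beyond the scatter). Compound 3 `N#Cc1cncc(N2C[C@@H]3CCNC[C@@H]32)c1` has the same atoms as compound 1 joined into a different core; the difference between the two cores is not broken down here. In this assay compound 3 gives 2560 nM, a number well above that of compound 1 and close to that of compound 2.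

Compound 4 `COc1cncc(N2C[C@@H]3CCNC[C@@H]32)c1` has not yet been measured. It differs from compound 3 in one place, (methoxy in place of cyano on an aromatic carbon), the same change that separates compound 2 from compound 1. Because that change once gave a 9.2-fold higher number from compound 1 to compound 2 (0.96 log units; beyond the scatter), a step of similar size, an 8.6-fold higher number from compound 3 to compound 4 (0.93 log units; beyond the scatter), is expected, although this rests on a single earlier example and on a different core. For compound 4 in this assay the estimated value is 22000 nM, with a likely range from 7000 nM to 70000 nM.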

Compound 4, half-maximal effective concentration: 63500 nM
Compound 4: the middle estimate sits 2.9-fold (0.46 log units) below what was measured, within the range that was stated.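

In this assay the swap of cyano for methoxy on the core of compound 3 gives a 25-fold higher number from compound 3 to compound 4 (1.39 log units; beyond the scatter) and so points the same way as on the core of compound 1. The direction of the change therefore carries over from one core to the other, but its size does not stay the same, as the two steps show when set side by side: the same change on two cores in this assay, a 9.2-fold higher number (0.96 log units; beyond the scatter) from compound 1 to compound 2 and a 25-fold higher number (1.39 log units; beyond the scatter) from compound 3 to compound 4, 2.7-fold (0.43 log units) apart, beyond the scatter of two such steps. Among the compounds shown here, with only two pairs in a single assay, this does not show that a further core would follow the same direction, and it does not tell what in the two cores makes the size differ.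

The compounds shown carry only cyano or methoxy at this place on the aromatic ring, so it stays open how a fluorine atom, an amine or a longer chain such as ethoxy would behave there on either core. Going by these compounds, it is also open whether the step from cyano to any such group would differ between the two cores as the step to methoxy does.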